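Four-Bromo Benzotriazole Side Chains: From Hydroxybutyl to Dihydroxypropyl

The compounds below may be only part of what the source reports. "The series", "measured", "known", "first", "only" and "open" are said of these compounds alone.

Measured compounds:
- compound 1 `C[C@@H](O)CCn1nc2c(Br)c(Br)c(Br)c(Br)c2n1` gives 81% in a functional assay on CCRF-CEM cells (Homo sapiens) for antiproliferative activity, read by MTT assay, with a stated time of 24 h, tested at 25 uM; on this read-out higher numbers stand for a weaker effect at the one concentration tested and lower numbers for a stronger effect
- compound 2 `C[C@H](O)CCn1nc2c(Br)c(Br)c(Br)c(Br)c2n1` gives 112% in this assay
- compound 3 `CC(O)CCn1nc2c(Br)c(Br)c(Br)c(Br)c2n1` gives 113% in this assay

Compound 3 stands highest of the three, with compound 2 nearest and within the scatter, and compound 1 furthest, a number 32 percentage points higher from compound 1 to compound 3 (beyond the scatter). The steps among the measured compounds, a number 31 percentage points higher from compound 1 to compound 2 (beyond the scatter) and a number 1 percentage points higher from compound 2 to compound 3 (within the scatter), concern only the drawn configuration at one chain carbon, as shown by the fact that compounds 1 and 2 differ only in the configuration as drawn, the fact that one of compounds 1 and 3 is drawn with a defined configuration and the other without, at the place where they differ and (the fact that one of compounds 2 and 3 is drawn with a defined configuration and the other without, at the place where they differ).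

Compound 4 `OCC(O)Cn1nc2c(Br)c(Br)c(Br)c(Br)c2n1` differs from compound 3 by 1,2-dihydroxyethyl in place of 2-hydroxypropyl on a saturated chain carbon bound to an aromatic nitrogen. Within the data shown here, no measured step changes the side chain in this way, so none bears directly on it. With nothing to point either way, the expectation for compound 4 is a value near compound 3, a number 8 percentage points lower from compound 3 to compound 4 (within the scatter), and compound 4 is estimated at 105%, between 70% and 130%.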

Compound 4, a percentage reported as activity, at one concentration (the size of the read-out at that concentration, not a potency): 89%
The estimate for compound 4 lay 16 percentage points above the measured number; the range from low to high includes it.
By their numbers in this assay, from the lowest: compounds 1 and 4 (each within the scatter of the next); then compounds 2 and 3 (each within the scatter of the next).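

Until now only the drawn configuration had moved the number, but here the side chain itself does: 1,2-dihydroxyethyl in place of 2-hydroxypropyl gives a stronger effect in this assay (a number 24 percentage points lower from compound 3 to compound 4 (beyond the scatter)) and (a number 23 percentage points lower from compound 2 to compound 4 (beyond the scatter)). Read against the chain drawn R, the same change shows no clear difference (a number 8 percentage points higher from compound 1 to compound 4 (within the scatter)), so its size at this position depends on the comparison compound. Nothing measured here gives a reason for this shift. Still open, as far as these compounds go, is whether drawn forms of compound 4 would separate as compounds 1 and 2 do, and how an amine or a carboxylic acid would read on this chain.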